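Series notes: iodo in place of a ring hydrogen

A few compounds are considered here, and "the series" means these few. Any claim that something is new, unique, unknown or untested is made for them only; others in the source may bear on it.

Measured so far in a functional assay on HT-29 cells (Homo sapiens) for inhibition, read by sulforhodamine B assay, with a stated time of 48 h; a higher number here means a weaker inhibitor of growth, a lower number a stronger inhibitor of growth:
compound 1 `O=C1C=COC(/C=C/c2ccccc2)C1` gives 124 uM
compound 2 `O=C1C=COC(/C=C/c2ccc(C(F)(F)F)cc2)C1` gives 33.3 uM
compound 3 `COc1ccc(C2CC(=O)C=CO2)cc1` gives 203 uM

Compound 3 stands with the highest of the three numbers. Against compound 1 the gap is within the scatter, so the two cannot be ordered; against compound 2 the gap is beyond the scatter, which puts compound 3 at the weak end of the set. Going by the values given here, the one step that can be read is a 3.7-fold lower number from compound 1 to compound 2 (0.57 log units; beyond the scatter), where a trifluoromethyl group enters on an aromatic carbon of the side chain.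

Compound 4 `COc1ccc(C2CC(=O)C(I)=CO2)cc1` differs from compound 3 by iodo in place of hydrogen on a double-bonded ring carbon. Among the compounds with values here, the change sits on the shared core rather than on the aromatic ring, so the step from compound 1 to compound 2 bears on it only loosely: it shows that a single entering group can move the number beyond the scatter, but no measured pair tests a substituent on that double-bonded ring carbon. A direct precedent is lacking. For the step of a 2.0-fold lower number from compound 3 to compound 4 (0.31 log units; beyond the scatter) the expectation is set cautiously: a lowering of the number is plausible but not established, and a wide range is kept. Compound 4 is expected to give 100 uM, within 35 uM to 300 uM, in this assay.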

Compound 4, concentration for growth inhibition (reported as GI): 24.4 uM
The estimate for compound 4 lay 4.1-fold (0.61 log units) above the measured number, and the stated range ends above it.
By their numbers in this assay, from the lowest: compounds 4 and 2 (each within the scatter of the next); then compounds 1 and 3 (each within the scatter of the next).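

In this assay, the double-bonded ring carbon two ring bonds from the ring oxygen responds to substitution: iodo in place of hydrogen gives an 8.3-fold lower number from compound 3 to compound 4 (0.92 log units; beyond the scatter) on the shared core itself. Going by these compounds alone, until now the only readable step lay on the aromatic ring of the side chain, so this is the first sign that a change on the core, three ring bonds from the ring atom that bears the group of 8 heavy atoms, can move the number beyond the scatter, and a single iodine atom is enough to do so. Nothing shown gives a reason for this step.

As far as these compounds go, with only one substituent at this carbon, it remains open whether the lowering is particular to iodo or would also appear with bromo, a nitrile or an amine at the same place. From the compounds shown here alone, it is also open whether iodo at this carbon lowers the number on the core of compound 1 or compound 2, which carry a different side chain, and whether it would add to the trifluoromethyl step.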